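This account rests on a few compounds, and the source may have more. Where it says the series, first, only, none or still open, it means among the compounds named here.

For the measured compounds named here, compound 1 `C[C@@H](Nc1nc(Cl)nc(NC(C)(C)C)n1)c1ccccc1` stands at the top of the three numbers known in an ADME assay on the whole organism for inhibition, with Oryza sativa as the target, with a stated time of 4 days (a lower number here means a stronger inhibitor, a higher number a weaker inhibitor), where compound 1 gives 9330 nM. Compound 2 `CC[C@H](C)Nc1nc(Cl)nc(N[C@@H](C)c2ccccc2)n1` gives 6920 nM in this assay, a number within the scatter of compound 1, while compound 3 `CCCN(CC)c1nc(Cl)nc(N[C@@H](C)c2ccccc2)n1` gives 479 nM, a step beyond the scatter relative to compound 1. The unmeasured compound 4 `CCN(CC)c1nc(Cl)nc(N[C@H](C)c2ccccc2)n1` differs from compound 1 in one place: diethylamino in place of (tert-butyl)amino on an aromatic carbon. The measured step that bears on this is a 14-fold lower number from compound 2 to compound 3 (1.16 log units; beyond the scatter), in which an amino group with one hydrogen-bond donor also gave way to one with no hydrogen-bond donors. A similarly large step toward a lower number is therefore expected, a 13-fold lower number from compound 1 to compound 4 (1.12 log units; beyond the scatter). Compound 4 is estimated at 700 nM, with a range from 250 nM to 2000 nM.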

Compound 4, half-maximal inhibitory concentration: 6310 nM
For compound 4 the middle estimate is 9.0-fold (0.95 log units) below the measured one, and the stated range ends below it.
By their numbers in this assay, from the lowest: compound 3; then compounds 4, 2 and 1 (each within the scatter of the next).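

At this position, an amino group with no hydrogen-bond donors does not by itself bring a large step: diethylamino in place of (tert-butyl)amino gives a 1.5-fold lower number from compound 1 to compound 4 (0.17 log units; within the scatter), against a 14-fold lower number from compound 2 to compound 3 (1.16 log units; beyond the scatter) with ethyl(propyl)amino in place of (sec-butyl)amino. For the compounds shown here, the loss of the donor therefore goes with a large step in only one of the two pairs, and those pairs differ in both the entering and the leaving group. Nothing available bears on why the two steps differ. Still open, from the compounds shown here alone, is whether dipropylamino, with its longer chains, or a ring amine such as piperidine would give a number nearer that of compound 3 or that of compound 4.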